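Swapping the aryl group on the ring nitrogen of compound 3

A few compounds are considered here, and "the series" means these few. Any claim that something is new, unique, unknown or untested is made for them only; others in the source may bear on it.

Compound 3 `O=C(Nc1ccc(Oc2ccncc2-c2cccnc2)c(F)c1)c1nn(-c2cccc(F)c2)c(=O)c2ccccc12` gives 27 nM in a functional assay on MKN-45 cells (Homo sapiens) for cytotoxicity, read by MTT assay, with a stated time of 72 h (a higher number here means a weaker inhibitor, a lower number a stronger inhibitor), the lowest of the three numbers recorded. Its nearest neighbour is compound 2 `Fc1cc(Nc2cc(Nc3cccc(Cl)c3)ncn2)ccc1Oc1ccncc1-c1cccnc1`, which in this assay gives 30 nM; the gap between them lies within the scatter. The furthest is compound 1 `COc1ccc(Nc2cc(Nc3ccc(Oc4ccncc4-c4cccnc4)c(F)c3)ncn2)cc1`, which gives 1010 nM, a gap well beyond the scatter.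

Compound 4 `O=C(Nc1ccc(Oc2ccncc2-c2cccnc2)c(F)c1)c1nn(-c2ccc(Cl)cc2)c(=O)c2ccccc12` differs from compound 3 in one place: 4-chlorophenyl in place of 3-fluorophenyl on an aromatic nitrogen. The aryl group carried on an aromatic nitrogen is replaced, with the halogen changing from fluorine to chlorine and moving to the 4-position of the phenyl ring.

Among the compounds with values here, only one measured step offers a comparison, and it sits on a different scaffold: a 34-fold lower number from compound 1 to compound 2 (1.53 log units; beyond the scatter). That step shows that exchanging one substituted phenyl for another on a nitrogen can move this assay a great deal, but it gives no firm direction for the present swap, and the two changes are not alike in detail.

The step is therefore expected to be modest, with a wide range allowed: a 1.1-fold higher number from compound 3 to compound 4 (0.05 log units; within the scatter). Compound 4 is estimated at 30 nM, between 8 nM and 120 nM.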

Compound 4, half-maximal inhibitory concentration: 430 nM
For compound 4 the middle estimate is 14-fold (1.16 log units) below the measured one, and the stated range ends below it.
By their numbers in this assay, from the lowest: compounds 3 and 2 (each within the scatter of the next); then compound 4; then compound 1.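

In this assay the exchange of 3-fluorophenyl for 4-chlorophenyl on the aromatic nitrogen gives a 16-fold higher number from compound 3 to compound 4 (1.20 log units; beyond the scatter) and takes the core of compound 3 away from its low number, although the two groups match in heavy atoms, hydrogen-bond donors, hydrogen-bond acceptors and charge. Within the data shown here, the earlier step, a 34-fold lower number from compound 1 to compound 2 (1.53 log units; beyond the scatter) on another core, showed only that a change of aryl group on a nitrogen can move this assay a long way; this step shows that the aromatic nitrogen of the present core is just as sensitive, here towards a higher number, even with a change confined to one halogen and where it sits on the phenyl ring. Nothing available here bears on why the number rises.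

The halogen and its position change together in this step, and the compounds shown do not separate the two: a 4-fluorophenyl or a 3-chlorophenyl on this same nitrogen would do so. From the compounds shown here alone, how this position would respond to a plain phenyl, or to a phenyl carrying an amine or a carboxylic acid, also remains open.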